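Chlorothiophene for methylthiophene: what one swap may bring

This account rests on a few compounds, and the source may have more. Where it says the series, first, only, none or still open, it means among the compounds named here.

Three compounds sharing a six-membered aromatic ring with one nitrogen were tested in an assay on isolated protein for inhibition of DNA topoisomerase 1 (Homo sapiens), with a stated time of 30 min, tested at 100 uM; on this read-out lower numbers stand for less inhibition and higher numbers for more inhibition at the one concentration tested (going by the name of the read-out). Compound 1 `Cc1ccsc1-c1cc(-c2ccco2)cc(-c2ccc(Cl)cc2)n1` gives 1%, compound 2 `Cc1ccsc1-c1cc(-c2ccoc2)cc(-c2ccco2)n1` gives 5.4%, and compound 3 `Clc1ccc(-c2cc(-c3ccco3)cc(-c3ccc(Cl)s3)n2)cc1` gives 53.1%. Compound 3 arises from compound 1 by 5-chlorothiophen-2-yl in place of 3-methylthiophen-2-yl on an aromatic carbon, and this change brought a number 52.1 percentage points higher from compound 1 to compound 3 (beyond the scatter). How the cores of compound 1 and compound 2 differ is not broken down here. Compound 4 `Clc1ccc(-c2cc(-c3ccoc3)cc(-c3ccco3)n2)s1`, not yet measured, arises from compound 2 by 5-chlorothiophen-2-yl in place of 3-methylthiophen-2-yl on an aromatic carbon. This is the same kind of change as that leading to compound 3, but around the place the group is meta to a furan-3-yl group rather than meta to a 4-chlorophenyl group. Going by the values given here, only one such step is known, so a smaller rise is expected: the step from compound 2 to compound 4 in this assay is estimated as a number 29.6 percentage points higher from compound 2 to compound 4 (beyond the scatter). Compound 4 is therefore expected to give 35%, most likely between 10% and 65%.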

Compound 4, a percentage reported as inhibition, at one concentration (the size of the read-out at that concentration, not a potency): 9.6%
Compound 4: middle estimate off by 25.4 percentage points, on the high side; the measured number lies below the stated range.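

In this assay the swap of 3-methylthiophen-2-yl for 5-chlorothiophen-2-yl did not carry over from one core to the other: the same change on two cores in this assay, a number 52.1 percentage points higher (beyond the scatter) from compound 1 to compound 3 and a number 4.2 percentage points higher (within the scatter) from compound 2 to compound 4, 47.9 percentage points apart, beyond the scatter of two such steps. On the core of compound 2 the swap gave a number 4.2 percentage points higher from compound 2 to compound 4 (within the scatter) and the large gain seen on the core of compound 1 therefore does not hold for every core in this series. The data do not show which feature of the two cores sets this gap, and two pairs give no rule for any further core.

The compounds shown leave open how the same swap behaves on a core carrying an amine or a carboxylic acid in place of the 4-chlorophenyl group. They also leave open whether a bromine or a methoxy group on the thiophene would follow the chlorine.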